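The source may hold more compounds than are shown below. What is called first, only, known or untested is meant among the compounds shown, and "the series" means these compounds.

Three compounds of one series have numbers in a functional assay, with a stated time of 20 min; on this read-out higher numbers stand for weaker inhibition and lower numbers for stronger inhibition. Compound 1 `CCOC(=O)c1cnn(-c2nc(-c3ccccc3Cl)c(C#N)c(=O)n2C)c1N` gives 78 ug/mL, compound 2 `CCOC(=O)c1cnn(-c2nc(-c3cccs3)c(C#N)c(=O)n2C)c1N` gives 79 ug/mL, and compound 3 `COc1ccc(-c2nc(NN)n(C)c(=O)c2C#N)cc1` gives 41 ug/mL. Compound 2 stands within the scatter of both neighbours: one step is a 1.0-fold higher number from compound 1 to compound 2 (0.01 log units; within the scatter), and the gap from compound 2 to compound 3 is also within the scatter of repeated measurements, so none of the three can be separated from the others on this read-out.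

Compound 4 `CCOC(=O)c1cnn(-c2nc(-c3cccc(O)c3O)c(C#N)c(=O)n2C)c1N` has not yet been measured. Relative to compound 2 it carries 2,3-dihydroxyphenyl in place of thiophen-2-yl on an aromatic carbon.

Among the measured compounds shown here, only one measured step touches the same position: the exchange of the aryl group from compound 1 to compound 2, which gave a 1.0-fold higher number from compound 1 to compound 2 (0.01 log units; within the scatter). For the measured compounds named here, the 2,3-dihydroxyphenyl group itself has no counterpart among the measured compounds, so the data give no direction for it. The account therefore expects a step of a 1.1-fold lower number from compound 2 to compound 4 (0.05 log units; within the scatter), with a wide range. Compound 4 is estimated at 70 ug/mL, between 30 ug/mL and 160 ug/mL.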

Compound 4, half-maximal inhibitory concentration: 41 ug/mL
Estimate against measurement, compound 4: 1.7-fold (0.23 log units) above; measured number inside the range.
By their numbers in this assay, from the lowest: compounds 3, 4, 1 and 2 (each within the scatter of the next).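

On the aromatic carbon ortho to a cyano group, three different aryl groups have now been read in this assay and none can be separated from the others. The 2,3-dihydroxyphenyl group, a six-membered carbon ring with 2 hydrogen-bond donors, gives a 1.9-fold lower number from compound 2 to compound 4 (0.28 log units; within the scatter) and also a 1.9-fold lower number from compound 1 to compound 4 (0.28 log units; within the scatter) so this position accepts a larger group bearing hydroxyl groups with no change beyond the scatter, although both steps sit close to its edge. Nothing measured on these compounds offers an explanation for these steps.

The compounds shown leave open whether one hydroxyl group alone, or a methoxy group in its place, would read the same as the 2,3-dihydroxyphenyl group. They also leave open whether an amine, a carboxylic acid or a longer chain at this position would move the number beyond the scatter.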